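Trimethylpyrazinylmethyl ether on a cinnamamide phenol: cytotoxicity estimate

A few compounds are considered here, and "the series" means these few. Any claim that something is new, unique, unknown or untested is made for them only; others in the source may bear on it.

Measured so far:
compound 1, `COc1cc(CNC(=O)/C=C/c2ccc(OCc3nc(C)c(C)nc3C)c(OC)c2)ccc1O`, 10200 nM
compound 2, `COc1cc(/C=C/C(=O)NCc2ccc(OCc3nc(C)c(C)nc3C)c(OC)c2)ccc1OCc1nc(C)c(C)nc1C`, 11100 nM
compound 3, `COc1cc(CNC(=O)/C=C/c2ccccc2OC)ccc1O`, 5980 nM

All three numbers come from a functional assay on SH-SY5Y cells (Homo sapiens) for cytotoxicity, read by MTT assay, with stated times of 24 h and 4 h; a higher number here means that more compound is needed for the effect, a lower number that less compound is needed. Compound 3 has the lowest of the three, but its gaps to compound 1 and compound 2 lie within the usual scatter, so no order among them is claimed. From compound 1 to compound 2 the change is (3,5,6-trimethylpyrazin-2-yl)methyl in place of hydrogen on an oxygen on an aromatic ring, and the step is a 1.1-fold higher number from compound 1 to compound 2 (0.04 log units; within the scatter). Compound 4, `COc1ccccc1/C=C/C(=O)NCc1ccc(OCc2nc(C)c(C)nc2C)c(OC)c1`, is made from compound 3 by the same change, ((3,5,6-trimethylpyrazin-2-yl)methyl in place of hydrogen on an oxygen on an aromatic ring), at the same kind of place. How the core of compound 3 differs from that of compound 1 is not broken down here. Because the earlier step was a 1.1-fold higher number from compound 1 to compound 2 (0.04 log units; within the scatter), compound 4 is expected to sit close to compound 3, with an estimated step of a 1.1-fold higher number from compound 3 to compound 4 (0.04 log units; within the scatter). The estimate for compound 4 in this assay is 6600 nM, likely between 3000 nM and 14000 nM.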

Compound 4, half-maximal effective concentration: 7150 nM
Beside the measured number, compound 4's estimate is 1.1-fold (0.03 log units) below it, and the stated range covers the measured number.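

In this assay, placing (3,5,6-trimethylpyrazin-2-yl)methyl on the oxygen of the aromatic ring gives a 1.2-fold higher number from compound 3 to compound 4 (0.08 log units; within the scatter). The same change on the two cores gives steps that do not differ: the same change on two cores in this assay, a 1.1-fold higher number (0.04 log units; within the scatter) from compound 1 to compound 2 and a 1.2-fold higher number (0.08 log units; within the scatter) from compound 3 to compound 4, 1.1-fold (0.04 log units) apart, within the scatter of two such steps. On these two cores, turning hydroxy into (3,5,6-trimethylpyrazin-2-yl)methoxy leaves the number within the usual scatter, but two pairs cannot show that this holds on other cores, and they show nothing about effects outside this cell assay.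

The compounds shown leave open what a group carrying an amine or a carboxylic acid would do on that oxygen. They also leave open whether a simple longer chain there would give a similarly small step.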